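The compounds below may be only part of what the source reports. "The series", "measured", "known", "first", "only" and "open" are said of these compounds alone.

The shared core carries a methoxy group, a primary carboxamide and a sulfonamide nitrogen. Compound 1, `COc1c(NS(=O)(=O)c2ccc(F)cc2)cc(-c2ccc3nc(NC(C)=O)nn3c2)cc1C(N)=O`, gives 25400 nM in a functional assay on HCT-116 cells (Homo sapiens) for antiproliferative activity, read by MTT assay, with a stated time of 72 h; a higher number here means a weaker inhibitor, a lower number a stronger inhibitor. Compound 2, `COc1c(NS(=O)(=O)C2CC2)cc(-c2ccc3nc(NC(C)=O)nn3c2)cc1C(N)=O`, gives 36300 nM in this assay. Within the data shown here, the one measured step, a 1.4-fold higher number from compound 1 to compound 2 (0.16 log units; within the scatter), concerns the group on the sulfonyl sulfur only.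

Compound 3, `COc1c(NS(=O)(=O)c2ccc(F)cc2)cc(-c2ccc3nc(NC4CC4)sc3c2)cc1C(N)=O`, carries a different ring system bearing a cyclopropylamino group. In this assay compound 3 reaches only a limit of the assay, > 50000 nM, so no number stands for it; this is where it sits, at the limit of > 50000 nM in this assay, at which 1 of the 3 values shown sits.

Compound 4, `COc1c(NS(=O)(=O)c2ccc(F)cc2)cc(-c2ccc3nc(NC(=O)C4CC4)sc3c2)cc1C(N)=O`, differs from compound 3 in one place: cyclopropylcarbonyl in place of cyclopropyl on a nitrogen on an aromatic ring. Among the measured compounds shown here, no measured step touches this position, and the step of a 1.4-fold higher number from compound 1 to compound 2 (0.16 log units; within the scatter) says nothing about it. The nearest point of comparison is the acetylamino group of compound 1 at 25400 nM and of compound 2 at 36300 nM, both on a different core, so no direction can be read with confidence.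

Compound 4 is therefore expected to stay weak, around 40000 nM, within a range of 15000 nM to 100000 nM. The estimated step of an at least 1.2-fold lower number from compound 3 to compound 4 (0.09 log units; that floor lies within the scatter) can only be set against a limit, and a result reported again as a limit is expected to be about as likely as a number.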

Compound 4, half-maximal inhibitory concentration: 2010 nM
The estimate for compound 4 lay 20-fold (1.30 log units) above the measured number; the measured number lies below the stated range.
By their numbers in this assay, from the lowest: compound 4; then compounds 1 and 2 (each within the scatter of the next). At a limit, above all of these: compound 3.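

In this assay, the nitrogen on the aromatic ring proves to be a place where a single change moves the number well beyond the scatter: the step is an at least 24-fold lower number from compound 3 to compound 4 (1.39 log units; beyond the scatter), whereas the change on the sulfonyl sulfur gave only a 1.4-fold higher number from compound 1 to compound 2 (0.16 log units; within the scatter). The cyclopropyl ring stands on both sides of the change, so what separates the two compounds at this position is the added carbonyl, with the hydrogen-bond acceptor counted for it. Compound 3 stands only at a limit of the assay, so the step gives a floor and not the full size of the change: the limit of > 50000 nM in this assay, at which 1 of the 4 values shown sits.

The compounds shown leave open whether other groups on this nitrogen, such as a urea, a carbamate or a longer acyl chain, would hold, improve or lose the number seen for compound 4. They also leave open whether cyclopropyl in place of 4-fluorophenyl on the sulfonyl sulfur would stay as small a step on the core of compound 4 as it was on the core of compound 1.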